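The source may report more compounds than this note shows. Statements on the series, on what has been measured and on what is new or still open speak of the compounds shown alone.

In a functional assay on PC-3 cells (Homo sapiens) for inhibition, with a stated time of 48 h, tested at 50 uM (on this read-out lower numbers stand for less inhibition of growth and higher numbers for more inhibition of growth at the one concentration tested), compound 1 `CC[C@](C)(CCCC(C)C)CCc1ccc(O)c(I)c1` gives 8% while compound 2 `COc1ccc(/C=C/[C@@](C)(/C=C/c2ccc(O)cc2)CCC=C(C)C)cc1` gives 50% and compound 3 `COc1ccc(/C=C/[C@@](C)(/C=C/c2ccc(O)cc2)CCC=C(C)C)cc1C=O` reaches 34% at the single concentration tested. Compound 3 thus stands second of the three, under compound 2 and over compound 1, with both gaps beyond the scatter. Compound 4 `COc1ccc(/C=C/[C@@](C)(/C=C/c2ccc(O)cc2)CCC=C(C)C)cc1CO` differs from compound 3 by the change hydroxymethyl in place of formyl on an aromatic carbon which puts hydroxymethyl in place of formyl on an aromatic carbon ortho to a methoxy group. Going by the values given here, the one measured step bearing on it is a number 16 percentage points lower from compound 2 to compound 3 (beyond the scatter) and it put formyl in place of hydrogen on that carbon. Among the compounds with values here, no measured step covers formyl giving way to hydroxymethyl, so only a small rise, perhaps within the scatter, is expected in this assay rather than a full return. The estimated change is a number 6 percentage points higher from compound 3 to compound 4 (within the scatter) and no more than that. Compound 4 is expected at 40% with 26% to 54% as the likely range.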

Compound 4, percent growth inhibition at one concentration: 39%
Compound 4: the middle estimate sits 1 percentage points above what was measured; measured number inside the range.
By their numbers in this assay, from the lowest: compound 1; then compounds 3 and 4 (each within the scatter of the next); then compound 2.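

Putting hydroxymethyl in place of formyl on this aromatic carbon, ortho to a methoxy group, gives in this assay a number 5 percentage points higher from compound 3 to compound 4 (within the scatter) and does not separate the two groups on this read-out. Set against hydrogen on the same carbon, hydroxymethyl gives a number 11 percentage points lower from compound 2 to compound 4 (beyond the scatter) and so the loss of growth inhibition is not confined to formyl. Nothing measured here explains this result. As far as these compounds go, whether an amine, a carboxylic acid or a methyl group on this carbon would also fall short of hydrogen stays open.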